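A few compounds are considered here, and "the series" means these few. Any claim that something is new, unique, unknown or untested is made for them only; others in the source may bear on it.

Of the compounds shown here, three built on a shared core have been tested in a functional assay on SH-SY5Y cells (Homo sapiens) for cytotoxicity, read by MTT assay, with stated times of 24 h and 4 h; on this read-out higher numbers stand for an effect only at larger amounts of compound and lower numbers for an effect already at smaller amounts. Compound 1 `COc1cc(CNC(=O)/C=C/c2ccccc2OCc2nc(C)c(C)nc2C)ccc1O` gives 12000 nM. Compound 2 `COc1cc(CNC(=O)/C=C/c2ccccc2O)ccc1OCc1nc(C)c(C)nc1C` gives 5300 nM, and compound 3 `COc1cc(CNC(=O)/C=C/c2ccc(OCc3nc(C)c(C)nc3C)c(OC)c2)ccc1O` gives 10200 nM. Compound 2 stands at the lower end of these three numbers: its gap to compound 3 lies within the usual scatter of repeated measurements, while its gap to compound 1 lies beyond that scatter, so compound 2 shows its effect at smaller amounts than compound 1 does.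

Compound 4 `COc1cc(CNC(=O)/C=C/c2ccc(OC)c(OC)c2OC)ccc1OCc1nc(C)c(C)nc1C` has not yet been measured in this assay. It differs from compound 2 in one place: 2,3,4-trimethoxyphenyl in place of 2-hydroxyphenyl on a double-bonded chain carbon bound to a double-bonded chain carbon. For the measured compounds named here, no measured pair among the three compounds shows a change of this kind, so the numbers at hand give no ground for a large step in either direction. In this assay the step expected is a 1.3-fold higher number from compound 2 to compound 4 (0.12 log units; within the scatter), a modest rise that should stay within the scatter. For compound 4 the estimate in this assay is 7000 nM, with a range from 3000 nM to 16000 nM.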

Compound 4, half-maximal effective concentration: 3840 nM
Beside the measured number, compound 4's estimate is 1.8-fold (0.26 log units) above it; the range from low to high includes it.
By their numbers in this assay, from the lowest: compounds 4, 2, 3 and 1 (each within the scatter of the next, the first and the last beyond it).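

Putting 2,3,4-trimethoxyphenyl in place of 2-hydroxyphenyl on a double-bonded chain carbon bound to a double-bonded chain carbon gives a 1.4-fold lower number from compound 2 to compound 4 (0.14 log units; within the scatter) in this assay, so this read-out does not tell the two compounds apart. For the compounds shown here, this is the first pair in the set that differs in only one place, and it shows that this place can carry either of these two substituted phenyl groups without a change beyond the scatter. Nothing at hand explains this result.

The exchange removes the hydroxyl and adds three methoxy groups in one step, so the compounds shown do not separate the contribution of each group. As far as these compounds go, it also remains open how the number would respond to a phenyl ring carrying an amine or a carboxylic acid at this place.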